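Chloro to fluoro exchange and cell tolerance in the series

A few compounds are considered here, and "the series" means these few. Any claim that something is new, unique, unknown or untested is made for them only; others in the source may bear on it.

Measured in an ADME assay on HEK-293T cells (Homo sapiens) for cytotoxicity, read by resazurin assay, with a stated time of 30 h; a lower number here means that less compound is tolerated, a higher number that more compound is tolerated:
compound 1 `O=C(Nc1ccc(N=C2NCCN2)cc1Cl)c1ccc(N=C2NCCN2)cc1` gives the assay limit > 200000 nM.
compound 2 `O=C(Nc1ccc(N=C2NCCN2)cc1F)c1ccc(N=C2NCCN2)cc1` gives the assay limit > 200000 nM.
compound 3 `O=C(Nc1ccc(N=C2NCCN2)c(Cl)c1)c1ccc(N=C2NCCN2)cc1` gives the assay limit > 200000 nM.

All three values are limits of this assay, not numbers, which is the whole of the limit of > 200000 nM in this assay, at which 3 of the 3 values shown sit. The change from compound 1 to compound 2, (fluoro in place of chloro on an aromatic carbon), therefore gives a step that the two limits leave unreadable from compound 1 to compound 2: the two limits leave its size unreadable.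

Compound 4 `O=C(Nc1ccc(N=C2NCCN2)c(F)c1)c1ccc(N=C2NCCN2)cc1` is not yet measured. It is made from compound 3 by fluoro in place of chloro on an aromatic carbon. The difference between the cores of compound 1 and compound 3 is not broken down here. The surroundings of the exchange also differ: in the first pair the carbon is ortho to a large group and meta to a group of 6 heavy atoms, in the second it is ortho to a group of 6 heavy atoms and meta to a large group, so this is the same kind of change, not the same change.

Since compound 3 sits at the limit > 200000 nM and the earlier pair stayed at the limit, the step from compound 3 to compound 4 is expected to be a number no higher from compound 3 to compound 4 (the limit leaves the size open). For compound 4 in this assay the expected value is 200000 nM, most likely again reported only as a limit.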

Compound 4, half-maximal cytotoxic concentration: > 200000 nM
Compound 4: no number, only a limit (the forecaster's own chance of this, stated with the estimate: 85%); the middle value sits exactly at the limit.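

In this assay compound 4 gives > 200000 nM, a limit and not a number. No step can be read between compound 3 and compound 4, as the series stays at a single limit: the limit of > 200000 nM in this assay, at which 4 of the 4 values shown sit.

The compounds shown leave open what concentration of compound 1, compound 2, compound 3 or compound 4 is tolerated, and whether fluoro and chloro differ at all in this read-out.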